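A methyl on the phenyl of compound 1

The compounds below may be only part of what the source reports. "The series", "measured", "known", "first", "only" and "open" are said of these compounds alone.

Measured so far in a functional assay on MDA-MB-231 cells (Homo sapiens) for antiproliferative activity, read by MTT assay, with a stated time of 48 h; a higher number here means a weaker inhibitor of growth, a lower number a stronger inhibitor of growth
- compound 1 `COC(=O)N1N=C(c2ccccc2)CC1c1cc(OC)c(OC)c(OC)c1` gives 1080 nM
- compound 2 `COc1cc(C2CC(c3ccccc3)=NN2C(=O)OCc2ccccc2)cc(OC)c1OC` gives > 10000 nM, which is a limit of the assay and not a number
- compound 3 `COC(=O)N1N=C(c2ccccc2)CC1c1ccc(OC)c(OC)c1` gives 8940 nM

Compound 1 has the lowest number of the two exact values, so it is the strongest inhibitor of growth among these three. The next change leads to compound 4 `COC(=O)N1N=C(c2cccc(C)c2)CC1c1cc(OC)c(OC)c(OC)c1` and puts methyl in place of hydrogen on an aromatic carbon, turning phenyl to 3-methylphenyl methyl in place of hydrogen on an aromatic carbon on the core of compound 1.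

Two measured steps offer a rough guide. Adding phenyl on a saturated chain carbon gave an at least 9.2-fold higher number from compound 1 to compound 2 (0.96 log units; beyond the scatter) and putting hydrogen in place of methoxy on an aromatic carbon gave an 8.3-fold higher number from compound 1 to compound 3 (0.92 log units; beyond the scatter) in the same assay. Neither step touches the phenyl that changes here, so they bear on it only loosely. For the measured compounds named here, no measured compound shows what a methyl does at this place.

Both changes raised the number, so a small rise is expected in this assay, well short of an 8.3-fold higher number from compound 1 to compound 3 (0.92 log units; beyond the scatter) as a guide to size. The estimate means a 1.5-fold higher number from compound 1 to compound 4 (0.17 log units; within the scatter) as the expected step. The expected value for compound 4 is 1600 nM, with an estimated range from 500 nM to 6000 nM.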

Compound 4, concentration for 50% growth inhibition: 140 nM
Compound 4: middle estimate off by 11-fold (1.06 log units), on the high side; the measured number lies below the stated range.
By their numbers in this assay, from the lowest: compound 4; then compound 1; then compound 3. At a limit, above all of these: compound 2.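

The phenyl of compound 1 turns out to be a place where a very small addition matters: in this assay, going from phenyl to 3-methylphenyl gives a 7.7-fold lower number from compound 1 to compound 4 (0.89 log units; beyond the scatter) and makes this the first step shown that lowers the number. The two earlier changes lay elsewhere on the molecule and only raised the number, so they showed what the shared core does not tolerate, not where a gain could be found; this step shows that one added carbon on this aromatic ring, with no ring, donor, acceptor or charge brought in, can move the number beyond the scatter. Nothing measured here accounts for why this single methyl has such an effect.

Only one group at one carbon of this ring is shown, so it remains open whether an ethyl, a chlorine or an amine on the same carbon would lower the number further, or raise it again. On these data alone, it is also open whether a methyl on another carbon of this ring would do the same, and whether the gain would carry over to the core of compound 3.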